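The compounds below may be only part of what the source reports. "The series", "measured", "known", "first", "only" and "open" are said of these compounds alone.

Compound 1 `CO[C@@H]1C/C=C(\C)C(=O)N(C)[C@@H](C(C)C)C(=O)N[C@H](Cc2ccccc2)C(=O)N[C@@H](C(C)C)C(=O)O[C@H](c2ccccc2)[C@H](C)/C=C/C=C/1C`: > 100 nM
Compound 2 `CO[C@@H]1C/C=C(\C)C(=O)N(C)[C@@H](C(C)C)C(=O)N[C@H](Cc2cc(Cl)c(O)c(Cl)c2)C(=O)N[C@@H](C(C)C)C(=O)O[C@H](c2ccccc2)[C@H](C)/C=C/C=C/1C`: 21.6 nM
Compound 3 `CC[C@H](C)[C@H]1C(=O)N[C@H](Cc2cc(Cl)c(O)c(Cl)c2)C(=O)N[C@@H](C(C)(C)O)C(=O)O[C@H](c2ccccc2)[C@H](C)/C=C/C=C(\C)[C@H](OC)C[C@@H]2O[C@@]2(C)C(=O)N1C`: 13.1 nM

All three were tested in a functional assay on A549 cells (Homo sapiens) for antiproliferative activity, read by MTT assay, with a stated time of 72 h; on this read-out lower numbers stand for stronger inhibition and higher numbers for weaker inhibition. Compound 2 gives 21.6 nM and compound 3 gives 13.1 nM; these two lie within the usual scatter of each other. For compound 1 the result is a limit, > 100 nM. How the cores of compound 2 and compound 3 differ is not broken down here. Compound 1 differs from compound 2 by phenyl in place of 3,5-dichloro-4-hydroxyphenyl on a saturated chain carbon bound to a saturated ring carbon, and the step is an at least 4.6-fold higher number from compound 2 to compound 1 (0.66 log units; beyond the scatter). That step rests on (the limit of > 100 nM in this assay, at which 1 of the 3 values shown sits), reached by compound 1.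

Compound 4 `CC[C@H](C)[C@H]1C(=O)N[C@H](Cc2ccccc2)C(=O)N[C@@H](C(C)(C)O)C(=O)O[C@H](c2ccccc2)[C@H](C)/C=C/C=C(\C)[C@H](OC)C[C@@H]2O[C@@]2(C)C(=O)N1C` is not yet measured. It differs from compound 3 by phenyl in place of 3,5-dichloro-4-hydroxyphenyl on a saturated chain carbon bound to a saturated ring carbon, the same change at the same place. Because an at least 4.6-fold higher number from compound 2 to compound 1 (0.66 log units; beyond the scatter), compound 4 is expected to show a 7.6-fold higher number from compound 3 to compound 4 (0.88 log units; beyond the scatter). Compound 4 is thus estimated at 100 nM, between 40 nM and 300 nM, with a fair chance that only a limit is reported.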

Compound 4, half-maximal inhibitory concentration: 14.3 nM
For compound 4 the middle estimate is 7.0-fold (0.84 log units) above the measured one; measured number outside the range, below it.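

In this assay, the exchange of 3,5-dichloro-4-hydroxyphenyl for phenyl gives a 1.1-fold higher number from compound 3 to compound 4 (0.04 log units; within the scatter). The effect of this change therefore does not carry over from one core to the other in this series: the same change on two cores in this assay, an at least 4.6-fold higher number (0.66 log units; beyond the scatter) from compound 2 to compound 1 and a 1.1-fold higher number (0.04 log units; within the scatter) from compound 3 to compound 4, at least 4.2-fold (0.62 log units) apart, beyond the scatter of two such steps Which of the differences between the two cores accounts for this is not shown, and the earlier step has a limit at one end: the limit of > 100 nM in this assay, at which 1 of the 4 values shown sits.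

Still open, on these data alone, is how a phenyl carrying only the chlorine atoms, only the hydroxyl, or a methoxy group in place of that hydroxyl would behave on each core. Also open, as far as these compounds go, is how the change would behave on a core that shares features of both.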